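Hydroxy to Benzyloxy: Estimating Activation by Compound 4

The compounds below may be only part of what the source reports. "The series", "measured", "known", "first", "only" and "open" are said of these compounds alone.

Compound 3 `Oc1cccc(-c2ccc(NCc3ccccc3O)cc2)c1` carries a free hydroxy group. In a functional assay on Jurkat cells (Homo sapiens) for activation, with a stated time of 24 h (a lower number here means that less compound is needed, a higher number that more compound is needed for the effect), compound 3 was reported as "not active" (no number reported), so no number stands for it, and its place on the numerical scale is simply not known. Its two close relatives do give numbers: compound 1 `Oc1ccccc1CNc1ccc(-c2cccc(F)c2)cc1` gives 2020 nM and compound 2 `Cc1cccc(-c2ccc(NCc3ccccc3O)cc2)c1` gives 9190 nM. Within the data shown here, the only step between measured compounds, a 4.5-fold higher number from compound 1 to compound 2 (0.66 log units; beyond the scatter), shows that a change at this same spot can move the read-out by a modest but real amount, and that a hydroxy group at that spot, as in compound 3, leaves the compound without any reported activity.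

Compound 4 `Oc1ccccc1CNc1ccc(-c2cccc(OCc3ccccc3)c2)cc1` differs from compound 3 by benzyl in place of hydrogen on an oxygen on an aromatic ring. Among the measured compounds shown here, no measured step matches a benzyl entering on an oxygen, and compound 3 offers no number from which a step could be computed, so the direction of the change cannot be read from the data; the step from compound 1 to compound 2 only shows the size a substituent change here can have. On that thin basis compound 4 is expected to give about 6000 nM in this assay, with an estimated range from 1500 nM to 30000 nM, and a real chance remains that it, like compound 3, is reported without a number.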

Compound 4, half-maximal effective concentration: "not active" (no number reported)
Compound 4 has no reported number here, and the estimate cannot be compared.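

With compound 3 and compound 4 both reported without a number in this assay, no new step can be read between them. The compounds shown leave open whether hydroxy to benzyloxy shifts the read-out at all, and where either compound stands on the numerical scale. Nothing shown here bears on why compound 4 gave this result.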